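Fluoro in place of hydrogen on compound 2

The source may hold more compounds than are shown below. What is called first, only, known or untested is meant among the compounds shown, and "the series" means these compounds.

Measured in a functional assay on A-431 cells (Homo sapiens) for antiproliferative activity, read by sulforhodamine B assay, with a stated time of 72 h; on this read-out higher numbers stand for weaker inhibition and lower numbers for stronger inhibition:
- compound 1 `C=C1CC(CBr)(c2ccc(F)cc2)OC1=O`: 800 nM
- compound 2 `C=C1CC(CI)(c2ccccc2)OC1=O`: 2720 nM

Compound 2 has the higher of the two numbers at 2720 nM, while compound 1 lies lower at 800 nM, a gap beyond the scatter. The next compound to be tested is compound 3 `C=C1CC(CI)(c2ccc(F)cc2)OC1=O`, which has fluoro in place of hydrogen on an aromatic carbon of compound 2: fluoro in place of hydrogen on an aromatic carbon. Among the measured compounds shown here, no measured pair shows this change alone, so the only guide is the lower value of compound 1 at 800 nM. A modest move to a lower number is expected in this assay, and it may not clear the scatter. The expected step is a 1.8-fold lower number from compound 2 to compound 3 (0.26 log units; within the scatter). For compound 3 the estimated value is 1500 nM, with an expected range of 600 nM to 3500 nM.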

Compound 3, half-maximal inhibitory concentration: 1900 nM
The estimate for compound 3 lay 1.3-fold (0.10 log units) below the measured number; the range from low to high includes it.
By their numbers in this assay, from the lowest: compound 1; then compounds 3 and 2 (each within the scatter of the next).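

In this assay, fluoro in place of hydrogen on an aromatic carbon gives a 1.4-fold lower number from compound 2 to compound 3 (0.16 log units; within the scatter), so on this single pair the change does not separate the two compounds. Among the compounds shown here, compound 3 also provides a one-place comparison at the saturated chain carbon: iodo in place of bromo gives a 2.4-fold higher number from compound 1 to compound 3 (0.38 log units; beyond the scatter), a modest step and the only one-place change here that clears the scatter. Nothing measured on these compounds bears on why either step has its size.

From the compounds shown here alone, each change rests on one pair, so it remains open whether fluoro gives a similar step with bromo on the chain carbon. Also open, going by these compounds, is how a chloro group on that chain carbon, or an amine or a carboxylic acid on the aromatic carbon, would read in this assay.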